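Swapping Chlorophenyl for Methylphenyl on a Weak Core

This account rests on a few compounds, and the source may have more. Where it says the series, first, only, none or still open, it means among the compounds named here.

Three related compounds have been tested in a functional assay on MCF7 cells (Homo sapiens) for cytotoxicity, read by MTT assay, with a stated time of 48 h; on this read-out lower numbers stand for stronger inhibition and higher numbers for weaker inhibition. Compound 1 `Fc1cccc(-c2nc(Nc3ccccc3)c3cc(F)ccc3n2)c1` gives 49700 nM in this assay, a very weak effect. Compound 2 `Fc1cccc(-c2nc(Nc3ccc(Cl)cc3)c3cc(F)ccc3n2)c1` reaches only the limit of this assay, > 50000 nM, which is a limit and not a number. Compound 3 `Fc1cccc(-c2nc(Nc3ccccc3Cl)c3cc(F)ccc3n2)c1` likewise stops at the limit of > 50000 nM. The measured steps are therefore unreadable in size: a number no lower from compound 1 to compound 2 (the limit leaves the size open), a number no lower from compound 1 to compound 3 (the limit leaves the size open), and a step that the two limits leave unreadable from compound 2 to compound 3. What can be said is that two of the three values sit at the limit of > 50000 nM in this assay, at which 2 of the 3 values shown sit, and the third lies close to it.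

Compound 4 `Cc1cccc(Nc2nc(-c3cccc(F)c3)nc3ccc(F)cc23)c1` differs from compound 2 in a single place: 3-methylphenyl in place of 4-chlorophenyl on a nitrogen on an aromatic ring. Among the measured compounds shown here, no measured step covers an exchange of this kind, and the steps that do exist give no size. With nothing pointing away from the limit region, compound 4 is expected to remain a very weak inhibitor in this assay, with an estimated 50000 nM and a range from 20000 nM to 150000 nM. The expected step of a number no higher from compound 2 to compound 4 (the limit leaves the size open) is thus estimated to be nothing beyond the usual scatter.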

Compound 4, half-maximal inhibitory concentration: > 50000 nM
Compound 4 ended at the assay's limit; the forecaster's own chance of this, stated with the estimate: 60%; the middle value sits exactly at the limit.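

In this assay compound 4 gives > 50000 nM, which is a limit and not a number. Set against the one true number in the series, the step is a number no lower from compound 1 to compound 4 (the limit leaves the size open). Every step to compound 4 holds at least one limit, so none of them can be read in size. The result still adds something: on a nitrogen on an aromatic ring, 3-methylphenyl, which carries no chlorine, ends at the limit just as 4-chlorophenyl and 2-chlorophenyl do, so reaching the limit is not confined to the chlorophenyl groups, and the set now gathers at one end of the scale: the limit of > 50000 nM in this assay, at which 3 of the 4 values shown sit.

Going by these compounds, how compound 2, compound 3 and compound 4 rank among themselves stays open, as none of them has a true number. Also open, on these data alone, is whether a different group on this nitrogen, such as a 4-aminophenyl or a 4-carboxyphenyl, would give a value clearly under the limit.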